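This account rests on a few compounds, and the source may have more. Where it says the series, first, only, none or still open, it means among the compounds named here.

Working notes on the series in a functional assay on HepG2 cells (Homo sapiens) for inhibition, read by MTT assay; a lower number here means a stronger inhibitor of growth, a higher number a weaker inhibitor of growth.

Three compounds carry the shared core of compound 1 `COc1cc2oc(-c3cccc(NC(=O)c4ccccc4Br)c3)cc(=O)c2c(OC)c1OC` with a benzamide on the pendant aryl amine. Compound 1 gives 23100 nM. Going by the values given here, compound 2 `COc1cc2oc(-c3cccc(NC(=O)c4ccc(F)cc4)c3)cc(=O)c2c(OC)c1OC` gives 47200 nM and stands highest of the three numbers so far: the step of a 2.0-fold higher number from compound 1 to compound 2 (0.31 log units; beyond the scatter) is modest, and the step of a 6.7-fold lower number from compound 2 to compound 3 (0.83 log units; beyond the scatter) is the largest in the set. Compound 3 `COc1cccc(C(=O)Nc2cccc(-c3cc(=O)c4c(OC)c(OC)c(OC)cc4o3)c2)c1` gives 7060 nM, the lowest number measured, and the step of a 3.3-fold lower number from compound 1 to compound 3 (0.51 log units; beyond the scatter) points the same way.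

Compound 4 `COc1ccccc1C(=O)Nc1cccc(-c2cc(=O)c3c(OC)c(OC)c(OC)cc3o2)c1` is next, differing from compound 2 in one place: 2-methoxyphenyl in place of 4-fluorophenyl on a carbonyl carbon. Among the compounds with values here, two measured steps bear on it. Moving from compound 2 to a methoxyphenyl, at a different position of the ring, gave a 6.7-fold lower number from compound 2 to compound 3 (0.83 log units; beyond the scatter); exchanging the 4-fluorophenyl for a ring substituted at the 2-position gave the reverse of a 2.0-fold higher number from compound 1 to compound 2 (0.31 log units; beyond the scatter), a smaller movement. A lower number than compound 2 is therefore expected for compound 4, by about a 3.1-fold lower number from compound 2 to compound 4 (0.50 log units; beyond the scatter), though a smaller gain than for compound 3 seems likely given that compound 1 stands at 23100 nM. The estimate for compound 4 is 15000 nM, within 5000 nM to 40000 nM.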

Compound 4, concentration for 50% growth inhibition: 7530 nM
The estimate for compound 4 lay 2.0-fold (0.30 log units) above the measured number; measured number inside the range.
By their numbers in this assay, from the lowest: compounds 3 and 4 (each within the scatter of the next); then compound 1; then compound 2.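

In this assay the 2-methoxyphenyl and the 3-methoxyphenyl on the carbonyl carbon cannot be told apart, with a 1.1-fold higher number from compound 3 to compound 4 (0.03 log units; within the scatter) as the step, so these two placements of the methoxy give no readable difference. Replacing the 4-fluorophenyl with the 2-methoxyphenyl gives a 6.3-fold lower number from compound 2 to compound 4 (0.80 log units; beyond the scatter) as a second step of note, which shows that the lower number seen with compound 3 is not confined to a single methoxyphenyl. Methoxy in place of bromo on an aromatic carbon gives a 3.1-fold lower number from compound 1 to compound 4 (0.49 log units; beyond the scatter) as its step, so at this one ring placement the identity of the group changes the number.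

Nothing measured here explains these differences. Open, going by these compounds, is whether a 4-methoxyphenyl, or a ring carrying an amine or a carboxylic acid in place of the methoxy, would hold the number in this assay or lose it.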